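Ester variation on a thiophene-prolinamide series: HUVEC growth inhibition

The source may report more compounds than this note shows. Statements on the series, on what has been measured and on what is new or still open speak of the compounds shown alone.

Measured compounds:
Compound 1, `O=C1CC[C@@H](COC(=O)c2ccsc2NC(=O)[C@@H]2CCCN2)N1`, gives 88.6 ug/mL in a toxicity assay on HUVEC cells (Homo sapiens) for inhibition; a higher number here means a weaker inhibitor of growth, a lower number a stronger inhibitor of growth.
Compound 2, `O=C(OC1CCCCC1)c1ccsc1NC(=O)[C@@H]1CCCN1`, gives 137 ug/mL in this assay.
Compound 3, `COC(=O)c1ccsc1NC(=O)[C@H]1CCCN1`, gives 95.8 ug/mL in this assay.

Compound 1 does not separate from the other two: its value lies within the scatter of compound 3 and within the scatter of compound 2, so the three numbers read as one level.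

Compound 4, `CCOC(=O)c1ccsc1NC(=O)[C@@H]1CCCN1`, has not yet been measured in this assay. It differs from compound 1 by methyl in place of 5-oxopyrrolidin-2-yl on a saturated chain carbon bound to an oxygen next to a carbonyl group. Within the data shown here, the only measured step on the same oxygen is a 1.5-fold higher number from compound 1 to compound 2 (0.19 log units; within the scatter), where a larger ring replaced the (5-oxopyrrolidin-2-yl)methyl group without a change beyond the scatter. Compound 3, bearing a methyl on that oxygen, gives a value that is likewise indistinguishable from compound 1. Two changes at this position have left the number where it was, so the shift to ethyl is expected to do the same: no step beyond the scatter in this assay, in either direction.

The expected step is a 1.1-fold higher number from compound 1 to compound 4 (0.05 log units; within the scatter). Compound 4 is therefore estimated at 100 ug/mL, with a range from 50 ug/mL to 200 ug/mL.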

Compound 4, concentration for 50% growth inhibition: > 250 ug/mL
Compound 4 gave a limit, no number; the forecaster's own chance of this, stated with the estimate: 5%; middle value at least 2.5-fold (0.39 log units) away from the limit.
By their numbers in this assay, from the lowest: compounds 1, 3 and 2 (each within the scatter of the next). At a limit, above all of these: compound 4.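

The position on a saturated chain carbon bound to an oxygen next to a carbonyl group does respond in this assay: replacing 5-oxopyrrolidin-2-yl with methyl gives an at least 2.8-fold higher number from compound 1 to compound 4 (0.45 log units; beyond the scatter), whereas the earlier exchange at this oxygen gave only a 1.5-fold higher number from compound 1 to compound 2 (0.19 log units; within the scatter). Among these compounds, the result against the cyclohexyl group is less firm: ethyl in place of cyclohexyl gives an at least 1.8-fold higher number from compound 2 to compound 4 (0.26 log units; that floor lies within the scatter), so compound 4 is not clearly separated from compound 2, and only the step from compound 1 establishes a shift. Compound 4 stands at a limit of the assay rather than at a number, which makes the size of each step a floor: the limit of > 250 ug/mL in this assay, at which 1 of the 4 values shown sits.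

As far as these compounds go, how far compound 4 lies past that limit remains open, and with it the true size of both steps. Also open, from the compounds shown here alone, is whether a longer chain such as butyl, or an ethyl chain ending in an amine or a carboxylic acid, would stay with compound 4 or fall back to the level shared by compound 1 and compound 2.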